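This account rests on a few compounds, and the source may have more. Where it says the series, first, only, none or still open, it means among the compounds named here.

Compound 2 `Cc1ccc(/C=C2\CN(CC(=O)O)c3c(C)cccc3C2=O)cc1` is measured in an assay on HL-60 cells for inhibition of glutathione S-transferase P (Homo sapiens), read by spectrophotometry, tested at 20 uM (a lower number here means less inhibition, a higher number more inhibition at the concentration tested (going by the name of the read-out)), at 46.8%, the highest of the two numbers recorded so far. For the measured compounds named here, its only neighbour, compound 1 `Cc1cccc2c1N(CC(=O)O)C/C(=C\c1ccc(F)cc1)C2=O`, gives 22.9% in this assay; the single step that connects them, a number 23.9 percentage points higher from compound 1 to compound 2 (beyond the scatter), goes with methyl in place of fluoro on an aromatic carbon. Compound 3 `Cc1cccc2c1N(CC(=O)O)C/C(=C\c1ccc(N(C)C)cc1)C2=O` has not yet been measured. It differs from compound 2 by dimethylamino in place of methyl on an aromatic carbon. Going by the values given here, no measured step exchanges this particular group, so the only guide is that the one recorded exchange at this position, from compound 1 to compound 2, moved the read-out by a modest amount beyond the scatter, and a further exchange there might again do so. Compound 3 is therefore expected to shift by about a number 5.2 percentage points higher from compound 2 to compound 3 (within the scatter). The estimated value for compound 3 is 52%, within a range from 28% to 76%.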

Compound 3, a percentage reported as inhibition, at one concentration (the size of the read-out at that concentration, not a potency): 13.2%
Estimate against measurement, compound 3: 38.8 percentage points above; measured number outside the range, below it.
By their numbers in this assay, from the lowest: compounds 3 and 1 (each within the scatter of the next); then compound 2.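

At this position, para to a large group on the aromatic ring, the exchange of methyl for dimethylamino in this assay brings a number 33.6 percentage points lower from compound 2 to compound 3 (beyond the scatter) and so undoes the gain seen with methyl. Dimethylamino and fluoro cannot be told apart here, with a number 9.7 percentage points lower from compound 1 to compound 3 (within the scatter) as the step between them, so among these three groups only methyl stands apart. More heavy atoms at this position therefore do not go with a higher number, since dimethylamino, with three, sits well under methyl, with one.

Nothing available explains why methyl stands apart from the other two groups. Going by these compounds, it also remains open whether another small carbon group such as ethyl would match methyl here, or whether methoxy or chloro would fall with fluoro and dimethylamino.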